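Swapping an ester chain for an aminohexyl chain

This account rests on a few compounds, and the source may have more. Where it says the series, first, only, none or still open, it means among the compounds named here.

compound 1 `Nc1cccc(Nc2c(C(=O)NCc3ccc(F)cc3)nc(Br)c3cccnc23)c1` gives 8000 nM
compound 2 `O=C(NCc1ccc(F)cc1)c1nc(Br)c2cccnc2c1N1CCNCC1` gives 4500 nM
compound 3 `COC(=O)CNc1c(C(=O)NCc2ccc(F)cc2)nc(Br)c2cccnc12` gives 5000 nM

In a functional assay on LNCaP cells (Homo sapiens) for cytotoxicity, read by MTT assay, with a stated time of 72 h (on this read-out lower numbers stand for stronger inhibition and higher numbers for weaker inhibition), compound 3 gives 5000 nM and lies within the scatter of both other compounds. Compound 4 `NCCCCCCNc1c(C(=O)NCc2ccc(F)cc2)nc(Br)c2cccnc12` keeps the shared core but differs from compound 3 in one place: 5-aminopentyl in place of methoxycarbonyl on a saturated chain carbon bound to a nitrogen on an aromatic ring in words, 5-aminopentyl in place of methoxycarbonyl on a saturated chain carbon bound to a nitrogen on an aromatic ring. Exchanging the group at this part of the core has so far given small steps: a 1.6-fold lower number from compound 1 to compound 3 (0.20 log units; within the scatter) and a 1.1-fold higher number from compound 2 to compound 3 (0.05 log units; within the scatter) both stay within the scatter. Among the compounds with values here, no measured compound carries a 6-aminohexyl chain, which leaves these steps as a loose guide. No step beyond the scatter is expected in this assay and the estimated step is a 1.3-fold lower number from compound 3 to compound 4 (0.10 log units; within the scatter) only. The estimated value for compound 4 is 4000 nM (expected range 1500 nM to 10000 nM).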

Compound 4, half-maximal inhibitory concentration: 8000 nM
Estimate against measurement, compound 4: 2.0-fold (0.30 log units) below, and the stated range covers the measured number.
By their numbers in this assay, from the lowest: compounds 2, 3, 1 and 4 (each within the scatter of the next).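

In this assay, exchanging the ester chain for the 6-aminohexyl chain on this nitrogen gives a 1.6-fold higher number from compound 3 to compound 4 (0.20 log units; within the scatter), while the other comparisons give a 1.8-fold higher number from compound 2 to compound 4 (0.25 log units; within the scatter) and no change at the digits printed from compound 1 to compound 4 (within the scatter). A long, ring-free chain ending in an amine therefore stays within the scatter of the 3-aminophenyl, piperazin-1-yl and ester-bearing groups. No supporting measurement explains why these numbers stay so close.

Going by these compounds, it remains open whether a carboxylic acid in place of the methyl ester, or a much shorter aminoethyl chain, would move the number beyond the scatter.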